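Replacing the amide arm with a trifluoromethylphenyl on the triazole

A few compounds are considered here, and "the series" means these few. Any claim that something is new, unique, unknown or untested is made for them only; others in the source may bear on it.

Compound 1 `CCOC(=O)C1=Cc2ccccc2OC1(OCc1cn(CC(=O)Nc2ccccc2Br)nn1)C(F)(F)F`: in a functional assay on DU-145 cells (Homo sapiens) for inhibition, read by MTT assay, with a stated time of 24 h (on this read-out higher numbers stand for weaker inhibition and lower numbers for stronger inhibition), compound 1 gives only a limit, > 150000 nM.
Compound 2 `CCOC(=O)C1=Cc2ccccc2OC1(OCc1cn(CC(=O)Nc2ccccc2F)nn1)C(F)(F)F`: compound 2 gives 33900 nM.
Compound 3 `CCOC(=O)C1=Cc2ccccc2OC1(OCc1cn(CC(=O)Nc2ccc(I)cc2Cl)nn1)C(F)(F)F`: compound 3 gives 24400 nM.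

Among the two numbers shown, compound 3 has the lower one, but its gap to compound 2, a 1.4-fold lower number from compound 2 to compound 3 (0.14 log units; within the scatter), lies within the scatter, so the two cannot be ordered. Compound 4 `CCOC(=O)C1=Cc2ccccc2OC1(OCc1cn(-c2cccc(C(F)(F)F)c2)nn1)C(F)(F)F` differs from compound 3 in this way: 3-(trifluoromethyl)phenyl in place of ((2-chloro-4-iodophenyl)carbamoyl)methyl on an aromatic nitrogen. For the measured compounds named here, every measured step, an at least 4.4-fold lower number from compound 1 to compound 2 (0.64 log units; beyond the scatter) and an at least 6.1-fold lower number from compound 1 to compound 3 (0.78 log units; beyond the scatter), changes only the aryl on the amide, none removes the amide arm itself, so no step bears directly on this change. Compound 4 is therefore expected to stay near compound 3, with a step of a 1.2-fold higher number from compound 3 to compound 4 (0.09 log units; within the scatter) and a wide range; compound 4 is estimated at 30000 nM, between 8000 nM and 150000 nM.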

Compound 4, half-maximal inhibitory concentration: > 150000 nM
Compound 4 was reported as a limit; the forecaster's own chance of this, stated with the estimate: 25%; at least 5.0-fold (0.69 log units) between middle value and limit.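

For the compounds shown here, putting 3-(trifluoromethyl)phenyl directly on the aromatic nitrogen removes the whole amide arm, which no earlier step did, and in this assay this weakens inhibition, with an at least 6.1-fold higher number from compound 3 to compound 4 (0.78 log units; beyond the scatter) and an at least 4.4-fold higher number from compound 2 to compound 4 (0.64 log units; beyond the scatter). The arm at this position therefore matters for compounds 2 and 3, whereas changing its aryl had left compound 3 within the scatter of compound 2. Compound 1 and compound 4 are both limits, so the step between them cannot be read: the limit of > 150000 nM in this assay, at which 2 of the 4 values shown sit.

Going by these compounds, it remains open whether the amide or its aryl carries the effect. A 3-(trifluoromethyl)phenyl on the amide, or an acetamide without the aryl, would separate the two.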